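A few compounds are considered here, and "the series" means these few. Any claim that something is new, unique, unknown or untested is made for them only; others in the source may bear on it.

The measured compounds:
compound 1, `Cc1ccc(NC(=O)CN2CCN(c3nnc(Cc4ccccc4)c4ccccc34)CC2)c(C)c1`, 181000 nM
compound 2, `Cc1ccc(NC(=O)CN2CCN(c3nnc(Cc4ccncc4)c4ccccc34)CC2)c(C)c1`, 240 nM

Both were tested in a functional assay on MDA-MB-231 cells (Homo sapiens) for cytotoxicity, read by MTT assay, with a stated time of 72 h; on this read-out higher numbers stand for weaker inhibition and lower numbers for stronger inhibition. Compound 1 gives the highest of the two numbers; its nearest neighbour is compound 2, reached by a 750-fold lower number from compound 1 to compound 2 (2.88 log units; beyond the scatter), with pyridin-4-yl in place of phenyl on a saturated chain carbon bound to an aromatic carbon. That step touches the group hanging from the shared core, not the amide end of the molecule.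

Compound 3, `O=C(CN1CCN(c2nnc(Cc3ccccc3)c3ccccc23)CC1)Nc1cccc(F)c1`, has not yet been measured. It differs from compound 1 at the amide end: 3-fluorophenyl in place of 2,4-dimethylphenyl on an amide-type nitrogen. For the measured compounds named here, the only measured step concerns a different part of the structure, so no measured step bears on this change, and the numbers give no ground to expect a large shift in either direction in this assay. Compound 3 is therefore expected to stay close to compound 1, with a step of a 1.2-fold lower number from compound 1 to compound 3 (0.08 log units; within the scatter) that may well lie within the scatter. Compound 3 is estimated at 150000 nM, with a range from 30000 nM to 600000 nM.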

Compound 3, half-maximal inhibitory concentration: 3730 nM
Estimate against measurement, compound 3: 40-fold (1.60 log units) above, outside the stated range (below it).
By their numbers in this assay, from the lowest: compound 2; then compound 3; then compound 1.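

The amide end of the molecule turns out not to be a silent position: in this assay, 3-fluorophenyl in place of 2,4-dimethylphenyl on the amide-type nitrogen gives a 49-fold lower number from compound 1 to compound 3 (1.69 log units; beyond the scatter). For the compounds shown here, until now, the only large step lay at the other end of the molecule, on the group hanging from the shared core, so this is the first sign that the number also responds to the aryl group on the amide, even though both groups count as a single six-membered aromatic ring of carbon with no hydrogen-bond donors or acceptors. Nothing shown here accounts for the size of this step.

The change removes two methyl groups and brings in a fluorine at once, so the compounds shown cannot tell whether the step follows from the loss of the methyl groups, the arrival of the fluorine, or the place of substitution, a question that an unsubstituted phenyl, a 3-methylphenyl or a 3-chlorophenyl on the same nitrogen would address. From the compounds shown here alone, it also remains open whether pyridin-4-yl and 3-fluorophenyl, each tied to a large step from compound 1, would add up when carried together in one molecule.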